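Swapping Nitrile for Chlorine on a Phenol Ring

The source may report more compounds than this note shows. Statements on the series, on what has been measured and on what is new or still open speak of the compounds shown alone.

Measured so far:
Compound 1, `CCC/N=C1\S/C(=C\c2ccc(O)c(C#N)c2)C(=O)N1c1ccccc1C`: 220000 nM
Compound 2, `CCC/N=C1\S/C(=C\c2ccc(O)c(Cl)c2)C(=O)N1c1ccccc1OC`: 79000 nM
Compound 3, `COCC/N=C1\S/C(=C\c2ccc(O)c(Cl)c2)C(=O)N1c1ccccc1C`: 110000 nM

Of the compounds shown here, three sharing one core have been tested in a physicochemical assay for solubility, measured as kinetic solubility; on this read-out lower numbers stand for lower solubility and higher numbers for higher solubility. Compound 1 sits at the top end of the three numbers. Compound 3 lies within the usual scatter of it, so the two cannot be told apart on this read-out. Compound 2 lies beyond the scatter below compound 1.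

The next compound, compound 4, `CCC/N=C1\S/C(=C\c2ccc(O)c(Cl)c2)C(=O)N1c1ccccc1C`, differs from compound 1 in one place: chloro in place of cyano on an aromatic carbon. Within the data shown here, no single-change pair among the measured compounds shows how this swap plays out, so the expectation rests on the surrounding numbers. Both compound 2 and compound 3 already carry the chloro group, though each also differs from compound 1 elsewhere; compound 3 gives 110000 nM, and compound 2 gives 79000 nM. A modest move downward is expected for the step of a 1.8-fold lower number from compound 1 to compound 4 (0.26 log units; within the scatter), small enough that it may still fall within the scatter.

Compound 4 is therefore estimated at 120000 nM in this assay, with a likely range from 50000 nM to 250000 nM.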

Compound 4, solubility: 79000 nM
Beside the measured number, compound 4's estimate is 1.5-fold (0.18 log units) above it; the range from low to high includes it.
By their numbers in this assay, from the lowest: compounds 2, 4, 3 and 1 (each within the scatter of the next, the first and the last beyond it).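

Read in this assay, chloro in place of cyano on the 3-cyano-4-hydroxyphenyl group can now be seen as a single change, and it gives a 2.8-fold lower number from compound 1 to compound 4 (0.44 log units; beyond the scatter) at this aromatic carbon, a step that stands clear of the usual scatter. The two single changes of methyl in place of methoxy, one on the saturated chain and one on the aromatic carbon, give a 1.4-fold lower number from compound 3 to compound 4 (0.14 log units; within the scatter) and no change at the digits printed from compound 2 to compound 4 (within the scatter) and cannot be told from the scatter, so among these three steps only the swap from cyano to chloro is a readable difference. Nothing in the data at hand explains the size of this step.

This is one swap on one background, so the compounds shown leave open whether the same step would appear with the methoxy-bearing groups or with a longer chain on the nitrogen. They also leave open how a carboxylic acid or an amine on this aromatic carbon would compare with cyano and chloro.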